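The source may report more compounds than this note shows. Statements on the series, on what has been measured and on what is new or still open speak of the compounds shown alone.

In an assay on isolated protein for inhibition of protein kinase C theta type (Homo sapiens), read by TR-FRET, with a stated time of 2 h (a higher number here means a weaker inhibitor, a lower number a stronger inhibitor), compound 1 `N#Cc1cnc(NCc2ccccc2C(F)(F)F)cc1N[C@H]1CC[C@H](O)CC1` gives 4000 nM. Compound 2 `CO[C@H]1CC[C@H](Nc2cc(NCc3cnccc3C(F)(F)F)ncc2C#N)CC1` gives 1100 nM in this assay, the lower of the two numbers, with a gap to compound 1 that lies beyond the usual scatter. Compound 3 `CC1(C)[C@@H](C(N)=O)C[C@H]1Nc1cc(NCc2cnccc2C(F)(F)F)ncc1C#N` differs from compound 2 in one place: 3-carbamoyl-2,2-dimethylcyclobutyl in place of 4-methoxycyclohexyl on a nitrogen on an aromatic ring. Going by the values given here, no measured pair shares this change, so the expectation rests on compound 2 alone. The expected step of a 1.8-fold lower number from compound 2 to compound 3 (0.26 log units; within the scatter) is a modest gain in potency. Compound 3 is therefore estimated at 600 nM in this assay, with a range from 150 nM to 2500 nM.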

Compound 3, half-maximal inhibitory concentration: 1.4 nM
The estimate for compound 3 lay 430-fold (2.63 log units) above the measured number, and the stated range ends above it.
By their numbers in this assay, from the lowest: compound 3; then compound 2; then compound 1.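

Placed on a nitrogen on an aromatic ring, 3-carbamoyl-2,2-dimethylcyclobutyl in place of 4-methoxycyclohexyl gives a 790-fold lower number from compound 2 to compound 3 (2.90 log units; beyond the scatter) in this assay, so this position can carry a very large change in potency. The swap alters the ring size, the substituents and the hydrogen-bond donor count all at once, so the step cannot be pinned on any one of them. Nothing available explains the gain. On these data alone, what remains open is which part of the new group matters. A carboxylic acid or a methyl ester in place of the carbamoyl on the same ring would begin to separate these parts.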